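A few compounds are considered here, and "the series" means these few. Any claim that something is new, unique, unknown or untested is made for them only; others in the source may bear on it.

Compound 1 `CSc1nc(NCc2ccccc2)c2ccccc2n1` is one of the two measured compounds. In a functional assay on MCF7 cells (Homo sapiens) for cytotoxicity, read by MTT assay, with a stated time of 72 h (on this read-out higher numbers stand for lower toxicity in this test and lower numbers for higher toxicity in this test), compound 1 gives > 100000 nM, which is a limit of the assay and not a number. Compound 2 `CSc1nc(NCCCCCO)c2ccccc2n1` is the other. In this assay compound 2 gives > 100000 nM, again a limit of the assay.

Compound 2 therefore stands at a limit, and the step that the two limits leave unreadable from compound 1 to compound 2 cannot be read, since both of its ends sit where the limit of > 100000 nM in this assay, at which 2 of the 2 values shown sit, indicates.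

Compound 3 `CSc1nc(Nc2ccccc2)c2ccccc2n1` has not been measured. It differs from compound 2 by phenyl in place of 5-hydroxypentyl on a nitrogen on an aromatic ring. The only measured step, the one from compound 1 to compound 2, is unreadable, so no measured step gives the size of this change in this assay; the two limits shown only say that neither measured compound reached a number.

Compound 3 is accordingly expected to remain at the same limit, with an expected step of a number no higher from compound 2 to compound 3 (the limit leaves the size open) not beyond the scatter. The estimate for compound 3 in this assay is 100000 nM, in a range from 30000 nM to 300000 nM.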

Compound 3, concentration lethal to 50% of the cells: > 100000 nM
Compound 3 ended at the assay's limit; the forecaster's own chance of this, stated with the estimate: 75%; the middle value sits exactly at the limit.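

Compound 2 and compound 3 both stand at a limit of the assay, so no step between them can be read in this assay: the limit of > 100000 nM in this assay, at which 3 of the 3 values shown sit.

The compounds shown leave open whether compound 1, compound 2 and compound 3 differ at all in this assay, and whether any change on the shared core would give a readable number.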